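The compounds below may be only part of what the source reports. "The series", "measured", "known", "first", "only" and "open" are said of these compounds alone.

Compound 1 `Nc1scc(CN2CCN(c3cccnc3)CC2)c1C(=O)c1ccc(Cl)cc1`: in a functional assay on CHO cells with adenosine receptor A1 (Homo sapiens) as the target, read by cAMP accumulation and immunoassay, with a stated time of 6 min, tested at 0.1 uM (on this read-out higher numbers stand for a weaker effect at the one concentration tested and lower numbers for a stronger effect), compound 1 gives 3.4%.
Compound 2 `Nc1scc(CN2CCN(C3CCCCCC3)CC2)c1C(=O)c1ccc(Cl)cc1`: in this assay compound 2 gives 13%.
Compound 3 `Nc1scc(CN2CCN(c3ccc(F)cc3F)CC2)c1C(=O)c1ccc(Cl)cc1`: in this assay compound 3 gives -17%.

Among these three, compound 3 gives the lowest number, and its steps to the other two lie beyond the scatter: a number 20.4 percentage points lower from compound 1 to compound 3 (beyond the scatter) and a number 30 percentage points lower from compound 2 to compound 3 (beyond the scatter). Compound 1 and compound 2 sit within the scatter of each other, a number 9.6 percentage points higher from compound 1 to compound 2 (within the scatter). Compound 4 `Nc1scc(CN2CCN(c3cccc(Cl)c3)CC2)c1C(=O)c1ccc(Cl)cc1` has not been measured; it differs from compound 3 in one place: 3-chlorophenyl in place of 2,4-difluorophenyl on an amine nitrogen in a ring. Both steps that end at compound 3 put 2,4-difluorophenyl onto the same ring nitrogen and lowered the number by a modest amount. Swapping that group for another six-membered aromatic ring of carbon only is expected to move the number back toward compound 1, an upward step of a number 12 percentage points higher from compound 3 to compound 4 (beyond the scatter). Compound 4 is therefore estimated to give -5% in this assay, within -25% to 15%.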

Compound 4, a percentage reported as activity, at one concentration (the size of the read-out at that concentration, not a potency): -20%
Compound 4: middle estimate off by 15 percentage points, on the high side; measured number inside the range.
By their numbers in this assay, from the lowest: compounds 4 and 3 (each within the scatter of the next); then compounds 1 and 2 (each within the scatter of the next).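

In this assay, 3-chlorophenyl and 2,4-difluorophenyl on the ring nitrogen read alike (a number 3 percentage points lower from compound 3 to compound 4 (within the scatter)), so the two different substitution patterns on a carbon-only aromatic ring make no measurable difference here. The gap to the other two groups also reappears with this second carbon-only aromatic ring (a number 33 percentage points lower from compound 2 to compound 4 (beyond the scatter); a number 23.4 percentage points lower from compound 1 to compound 4 (beyond the scatter)). No measurement shown here explains these results. Going by these compounds, it remains open whether an unsubstituted phenyl, a benzyl group or a small alkyl group such as methyl on this nitrogen would read like compounds 3 and 4.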